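Ring closure of an amino alcohol: what to expect for compound 3

The source may hold more compounds than are shown below. What is called first, only, known or untested is meant among the compounds shown, and "the series" means these compounds.

Measured so far in an assay on isolated protein for inhibition of sphingosine kinase 1 (Homo sapiens), read by mobility shift assay; a higher number here means a weaker inhibitor, a lower number a stronger inhibitor:
compound 1, `CCCCCCCCc1ccc(NC(=O)[C@H](CO)NC)cc1`, gives 2800 nM
compound 2, `CCCCCCCCc1ccc(NC[C@@H](N)CO)cc1`, gives 5000 nM

Going by the values given here, only two numbers exist, and the single step that connects them, a 1.8-fold higher number from compound 1 to compound 2 (0.25 log units; within the scatter), stays within the scatter, so compound 2 and compound 1 cannot be told apart in this assay. Compound 3, `CCCCCCCCc1ccc(NC[C@H]2NCC[C@@H]2O)cc1`, has not yet been measured. It differs from compound 2 in one place: 3-hydroxypyrrolidin-2-yl in place of 1-amino-2-hydroxyethyl on a saturated chain carbon bound to a nitrogen on an aromatic ring. Among the compounds with values here, no measured step touches this ring closure; the one step known changed a different part of the molecule and was small. With nothing pointing up or down, the step expected in this assay is a 1.3-fold lower number from compound 2 to compound 3 (0.10 log units; within the scatter), meaning no change beyond the scatter. Compound 3 is therefore estimated at 4000 nM, expected to fall between 1500 nM and 12000 nM.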

Compound 3, half-maximal inhibitory concentration: 740 nM
Compound 3: the middle estimate sits 5.4-fold (0.73 log units) above what was measured; measured number outside the range, below it.
By their numbers in this assay, from the lowest: compound 3; then compounds 1 and 2 (each within the scatter of the next).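

Closing the open 1-amino-2-hydroxyethyl group into 3-hydroxypyrrolidin-2-yl, on a saturated chain carbon bound to a nitrogen on an aromatic ring, gives in this assay a clear change, a 6.8-fold lower number from compound 2 to compound 3 (0.83 log units; beyond the scatter) and so the first sign that this part of the molecule affects the result. Going by these compounds alone, the earlier pair could not show this, as its only step stayed within the scatter. The ring-bearing group also separates from the open amide-linked group, with a 3.8-fold lower number from compound 1 to compound 3 (0.58 log units; beyond the scatter) as the second step beyond the scatter. No measurement here explains the difference.

Going by these compounds, it remains open whether the hydroxyl group on the ring is needed, or whether a plain pyrrolidine or a six-membered piperidine would do as well. The mirror-image arrangement of the two stereocentres and a longer chain in place of the octyl chain also remain to be judged.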